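A few compounds are considered here, and "the series" means these few. Any claim that something is new, unique, unknown or untested is made for them only; others in the source may bear on it.

Compound 1 `O=C(CCc1cccc2c1B(O)OC2)Nc1ccccc1`: 350 nM
Compound 2 `Cc1ccc(NC(=O)CCc2cccc3c2B(O)OC3)cc1`: 4500 nM

Of these two numbers in a functional assay on HCT-116 cells (Homo sapiens) for antiproliferative activity, read by MTT assay, with a stated time of 72 h (a higher number here means a weaker inhibitor, a lower number a stronger inhibitor), compound 1 holds the lowest. Within the data shown here, the only measured step, a 13-fold higher number from compound 1 to compound 2 (1.11 log units; beyond the scatter), came from methyl in place of hydrogen on an aromatic carbon. Compound 3 `O=C(CCc1cccc2c1B(O)OC2)Nc1cccc(-c2cccc(C(F)(F)F)c2)c1` differs from compound 1 by 3-(trifluoromethyl)phenyl in place of hydrogen on an aromatic carbon, a much larger group entering the same ring, meta to a large group. Among the measured compounds shown here, only that one step bears on this change, and it was large; a weakening beyond the scatter in this assay is expected, though its size is uncertain, the group and place both differing. Compound 3 is estimated at 1500 nM, range 300 nM to 8000 nM, an expected step of a 4.3-fold higher number from compound 1 to compound 3 (0.63 log units; beyond the scatter).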

Compound 3, half-maximal inhibitory concentration: 580 nM
For compound 3 the middle estimate is 2.6-fold (0.41 log units) above the measured one; the range from low to high includes it.
By their numbers in this assay, from the lowest: compounds 1 and 3 (each within the scatter of the next); then compound 2.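

In this assay, 3-(trifluoromethyl)phenyl on an aromatic carbon, meta to a large group, gave a 1.7-fold higher number from compound 1 to compound 3 (0.22 log units; within the scatter), so a group of 10 heavy atoms is tolerated at this place. Among these compounds, the only earlier step, a 13-fold higher number from compound 1 to compound 2 (1.11 log units; beyond the scatter), came from the much smaller methyl at a different place, so size alone does not set the outcome across these compounds. Nothing measured here accounts for this contrast. On these data alone, it remains open whether a methyl or an amine at this same place would stay as close to compound 1, and whether a carboxylic acid could replace the trifluoromethyl on the added ring.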